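Positional isomer of the dimethoxyphenoxy tail in a piperidine ester series

The source may hold more compounds than are shown below. What is called first, only, known or untested is meant among the compounds shown, and "the series" means these compounds.

Compound 1 `COc1ccc(OCCCCCN2CCCC(COC(=O)c3ccccc3N3C(=O)CC(C)C3=O)C2)cc1OC` was tested in an in vitro functional assay on HEK ts201 cells for antagonist activity at Neuronal acetylcholine receptor; alpha4/beta2 (Homo sapiens), read by fluorescence and calcium flux; a higher number here means a weaker inhibitor, a lower number a stronger inhibitor. In this assay compound 1 gives 8320 nM. Within the data shown here, the only other compound measured, compound 2 `O=C(OCC1CCCN(CCCc2ccccc2)C1)c1ccc(-c2ccccc2)cc1`, gives 6310 nM in this assay, and the two values lie within the scatter of each other, so the two numbers on record do not separate the compounds. Among the measured compounds shown here, no pair of measured compounds differs in a single place, so no measured step is available to guide the next change.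

Compound 3 `COc1cccc(OCCCCCN2CCCC(COC(=O)c3ccccc3N3C(=O)CC(C)C3=O)C2)c1OC` has not yet been measured. It differs from compound 1 in one place: 2,3-dimethoxyphenyl in place of 3,4-dimethoxyphenyl on an oxygen on a saturated carbon, with the two compounds holding the same atoms joined differently. With no measured step of this kind in the series, the expected change is none beyond the scatter. The expected step is a 1.0-fold higher number from compound 1 to compound 3 (0.01 log units; within the scatter), which is taken to lie within the scatter. Compound 3 is expected to give 8500 nM in this assay, with a range from 3000 nM to 25000 nM.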

Compound 3, half-maximal inhibitory concentration: 8710 nM
Compound 3: the middle estimate sits 1.0-fold (0.01 log units) below what was measured, within the range that was stated.
By their numbers in this assay, from the lowest: compounds 2, 1 and 3 (each within the scatter of the next).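

Among these compounds, replacing 3,4-dimethoxyphenyl with 2,3-dimethoxyphenyl on an oxygen on a saturated carbon gives the first single-place comparison: in this assay the step reads a 1.0-fold higher number from compound 1 to compound 3 (0.02 log units; within the scatter), which lies within the scatter, so this pair of isomers is not separated. The two groups hold the same atoms and the same counts of rings, donors and acceptors, and at this position the assay does not distinguish these two arrangements of the methoxy groups, although one pair sets no pattern for other groups at this place. No measurement is available that bears on why the two isomers read alike.

Going by these compounds, it remains open whether this assay would separate compound 1 from an analogue with a larger departure at this place, such as an amine or a carboxylic acid on the phenyl ring in place of the methoxy groups, or a longer chain between the phenoxy oxygen and the ring nitrogen. Also open, on these data alone, is whether the same exchange of dimethoxyphenyl groups would read alike on a different core.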